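Chain Length at the Imine Nitrogen: Notes on Compound 4

A few compounds are considered here, and "the series" means these few. Any claim that something is new, unique, unknown or untested is made for them only; others in the source may bear on it.

Measured so far in a functional assay on MDA-MB-231 cells (Homo sapiens) for antiproliferative activity, read by WST assay, with a stated time of 72 h; on this read-out lower numbers stand for stronger inhibition and higher numbers for weaker inhibition:
- compound 1, `CCCCCCCC/N=c1\nc(N)c2ncn(Cc3ccc(OC)cc3)c2c(N)n1`: 2550 nM
- compound 2, `CCCCCCCC/N=c1\nc(N)c2ncn(Cc3ccc(F)cc3)c2c(N)n1`: 3600 nM
- compound 3, `CC/N=c1\nc(N)c2nc[nH]c2c(N)n1`: "not active" (no number reported)

Compound 3 stands apart from the other two: in this assay compound 3 is recorded as "not active" (no number reported), with no number behind it, so it cannot be ranked against compound 1 or compound 2 on a scale. Going by the values given here, compound 1 and compound 2 both carry the octyl chain on the double-bonded nitrogen together with a substituted benzyl group on the shared core, and the only measured step, a 1.4-fold higher number from compound 1 to compound 2 (0.15 log units; within the scatter), concerns that aromatic substituent alone.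

Compound 4, `CCCCCCCC/N=c1\nc(N)c2nc[nH]c2c(N)n1`, is compound 3 with hexyl in place of hydrogen on a saturated chain carbon, two bonds along the chain from a double-bonded nitrogen. Among the compounds with values here, no measured step touches the chain on the double-bonded nitrogen, so the one step on record gives no direct guide to the size or direction of this change in this assay. What can be said is that compound 4 shares the octyl chain with compound 1 and compound 2 but lacks the benzyl group both of them carry.

Compound 4 is therefore expected to give a weaker result than compound 1 and compound 2 in this assay, estimated at 9000 nM, with a range from 2500 nM to 40000 nM, and a real chance that only a limit is reported.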

Compound 4, half-maximal inhibitory concentration: "not active" (no number reported)
Nothing numeric was reported for compound 4, and the estimate cannot be compared.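

In this assay compound 3 gives "not active" (no number reported) and compound 4 gives "not active" (no number reported), so no new step can be read between the two. The compounds shown leave open what part the substituted benzyl group, carried by compound 1 and compound 2 but absent from compound 4, plays in activity. No supporting evidence bears on this result.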